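The source may hold more compounds than are shown below. What is called first, only, known or untested is meant among the compounds shown, and "the series" means these compounds.

Measured compounds and their values:

Compound 1 `COc1ccc(Oc2ccccc2-c2ccsc2S(=O)(=O)N2CCN(C(=O)Nc3ccc([N+](=O)[O-])cc3)CC2)cc1OC` — in a functional assay on HL-60 cells (Homo sapiens) for inhibition, read by CCK-8 assay, with a stated time of 48 h (a higher number here means a weaker inhibitor, a lower number a stronger inhibitor), compound 1 gives > 50000 nM, a limit of the assay rather than a number.
Compound 2 `COc1ccc(Oc2ccc(C(C)C)cc2-c2ccsc2S(=O)(=O)NCCNC(=S)Nc2cc(C(F)(F)F)cc(C(F)(F)F)c2)cc1OC` — in this assay compound 2 gives 6900 nM.
Compound 3 `O=C(Nc1ccc([N+](=O)[O-])cc1)N1CCN(S(=O)(=O)c2sccc2-c2ccccc2Oc2ccc(O)c(O)c2)CC1` — in this assay compound 3 gives 4900 nM.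

Compound 1 and compound 3 share one core and differ in a single place: 3,4-dihydroxyphenyl in place of 3,4-dimethoxyphenyl on an oxygen on an aromatic ring. That change produced a step of an at least 10-fold lower number from compound 1 to compound 3 (1.00 log units; beyond the scatter). The size of this step is known only as a floor, as reflected in the limit of > 50000 nM in this assay, at which 1 of the 3 values shown sits. Compound 2 is built on a different core; the difference between the two cores is not broken down here. The values of compound 2 and compound 3 lie within the scatter of each other, so no order between them can be read.

Compound 4 `CC(C)c1ccc(Oc2ccc(O)c(O)c2)c(-c2ccsc2S(=O)(=O)NCCNC(=S)Nc2cc(C(F)(F)F)cc(C(F)(F)F)c2)c1` has not yet been measured. Within the data shown here, it differs from compound 2 by 3,4-dihydroxyphenyl in place of 3,4-dimethoxyphenyl on an oxygen on an aromatic ring, which is the same change, at the same place, as the one between compound 1 and compound 3. The expected step here is a 4.6-fold lower number from compound 2 to compound 4 (0.66 log units; beyond the scatter), put somewhat smaller than the earlier step of an at least 10-fold lower number from compound 1 to compound 3 (1.00 log units; beyond the scatter), on the grounds that compound 2 already gives a number at 6900 nM. The earlier step, by contrast, began from compound 1, whose value is a limit of the assay. Compound 4 is therefore estimated at 1500 nM in this assay, most likely falling between 500 nM and 5000 nM.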

Compound 4, half-maximal inhibitory concentration: 8200 nM
For compound 4 the middle estimate is 5.5-fold (0.74 log units) below the measured one; the measured number lies above the stated range.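

In this assay, putting 3,4-dihydroxyphenyl in place of 3,4-dimethoxyphenyl on the core of compound 2 gave a 1.2-fold higher number from compound 2 to compound 4 (0.07 log units; within the scatter), so on this core the change has no readable effect, and the large step seen on the core of compound 1 did not carry over: the same change on two cores in this assay, an at least 10-fold lower number (1.00 log units; beyond the scatter) from compound 1 to compound 3 and a 1.2-fold higher number (0.07 log units; within the scatter) from compound 2 to compound 4, at least 12-fold (1.08 log units) apart, beyond the scatter of two such steps. Compound 1 gives > 50000 nM, which is a limit of the assay and not a number, so the step starting from it is known only as a floor, and the true gap between the two steps could be larger than the one printed. The result shows that the effect of this change depends on the core in these two pairs, but it does not show which of the several differences between the two cores is responsible, and two pairs cannot support a rule for the whole series.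

As far as these compounds go, it remains open whether a third core would follow compound 1 and compound 3 or compound 2 and compound 4. Also open, from the compounds shown here alone, is how a phenyl ring carrying one hydroxyl and one methoxy group on that same oxygen would behave on each core, which could show whether both hydroxyl groups are needed for the step seen on the core of compound 1.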